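Swapping trifluoromethyl for hydrogen on compound 2

A few compounds are considered here, and "the series" means these few. Any claim that something is new, unique, unknown or untested is made for them only; others in the source may bear on it.

In a functional assay on A549 cells (Homo sapiens) for antiproliferative activity, read by MTT assay, with a stated time of 48 h (a lower number here means a stronger inhibitor, a higher number a weaker inhibitor), compound 2 `COc1ccc(/C=C/c2cc(OC)cc(OC)c2/C=C/C(=O)c2ccc(C(F)(F)F)cc2)cc1` gives 7.8 ug/mL and compound 1 `CCCC(C)Oc1ccc(C(=O)/C=C/c2c(/C=C/c3ccc(OC)cc3)cc(OC)cc2OC)cc1` gives 9.4 ug/mL as its value, so the two lie within the usual scatter of each other. Compound 3 `COc1ccc(/C=C/c2cc(OC)cc(OC)c2/C=C/C(=O)c2ccccc2)cc1` has hydrogen in place of trifluoromethyl on an aromatic carbon. Among the measured compounds shown here, the only measured guide is a 1.2-fold lower number from compound 1 to compound 2 (0.08 log units; within the scatter) for trifluoromethyl in place of 1-methylbutoxy on an aromatic carbon. No step beyond the scatter is therefore expected in this assay and the estimated step is a 1.2-fold higher number from compound 2 to compound 3 (0.06 log units; within the scatter) for this swap. Compound 3 is estimated at 9 ug/mL within an expected range from 4.5 ug/mL to 18 ug/mL on measurement.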

Compound 3, half-maximal inhibitory concentration: 3.9 ug/mL
The estimate for compound 3 lay 2.3-fold (0.36 log units) above the measured number; the measured number lies below the stated range.
By their numbers in this assay, from the lowest: compounds 3, 2 and 1 (each within the scatter of the next, the first and the last beyond it).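

With hydrogen at this place on the ring, this assay shows its first step beyond the scatter, a modest one: a 2.4-fold lower number from compound 1 to compound 3 (0.38 log units; beyond the scatter) for hydrogen in place of 1-methylbutoxy. The step of a 2.0-fold lower number from compound 2 to compound 3 (0.30 log units; within the scatter) for hydrogen in place of trifluoromethyl stays within the scatter, so this position tolerates all three groups with only small differences in the number. No supporting measurement bears on why these numbers differ.

The compounds shown leave open how an amine or a carboxylic acid would read at this position. They also leave open where a shorter chain such as ethoxy would fall.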